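A Phenyl Gives Way to an Isopentyl Chain

This account rests on a few compounds, and the source may have more. Where it says the series, first, only, none or still open, it means among the compounds named here.

Three measured compounds stand in an assay on cells for agonist activity at ecdysone receptor (Bombyx mori), read by a luciferase reporter, with a stated time of 24 h; a higher number here means that more compound is needed for the effect, a lower number that less compound is needed. Compound 1 `CC(C)(C)N(NC(=O)c1ccccc1)C(=O)c1ccccc1I` gives 105 nM, compound 2 `CC(C)(C)N(NC(=O)c1cccc(F)c1)C(=O)c1ccccc1Cl` gives 69.2 nM, and compound 3 `CCc1ccc(C(=O)NN(C(=O)c2ccccc2)C(C)(C)C)cc1` gives 4.9 nM, the lowest of the three; the gaps to both others lie beyond the scatter of repeated measurements, so compound 3 is the most potent of the set. Compound 4 `CCc1ccc(C(=O)NN(C(=O)CCC(C)C)C(C)(C)C)cc1` differs from compound 3 in one place: isopentyl in place of phenyl on a carbonyl carbon. Among the measured compounds shown here, no pair of measured compounds shows this change, so its size cannot be read from the data. Compound 4 is expected to need more compound to reach the effect. The step of a 41-fold higher number from compound 3 to compound 4 (1.61 log units; beyond the scatter) is estimated to lie well beyond the scatter. In this assay compound 4 is therefore estimated at 200 nM, within a range from 30 nM to 2000 nM.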

Compound 4, half-maximal effective concentration: 832 nM
Beside the measured number, compound 4's estimate is 4.2-fold (0.62 log units) below it; measured number inside the range.
By their numbers in this assay, from the lowest: compound 3; then compounds 2 and 1 (each within the scatter of the next); then compound 4.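

Among the compounds shown here, putting isopentyl in place of phenyl on this carbonyl carbon gives a 170-fold higher number from compound 3 to compound 4 (2.23 log units; beyond the scatter) in this assay, the first step in the set that isolates a single place. It shows that this position does not tolerate the exchange of the aromatic ring for this open chain without a large rise in the number. Nothing available accounts for the size of this step.

On these data alone, whether a cyclohexyl ring, a pyridine ring or a shorter chain at this place would stay closer to compound 3 remains open.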